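A Methyl Added to the Weakest of Three Compounds

The source may report more compounds than this note shows. Statements on the series, on what has been measured and on what is new or still open speak of the compounds shown alone.

Compound 3 `COc1cccc(-c2cc(O)c3cccnc3n2)c1` and compound 1 `COc1cccc(-c2cc(O)c3cc(C)cnc3n2)c1` share one core and differ only by methyl in place of hydrogen on an aromatic carbon. In a functional assay on U-251 cells (Homo sapiens) (a lower number here means a stronger inhibitor of growth, a higher number a weaker inhibitor of growth), compound 3 gives 55 nM, while compound 1 gives 44.7 nM. The step between them is a 1.2-fold lower number from compound 3 to compound 1 (0.09 log units; within the scatter), so adding the methyl left the read-out essentially where it was.

Compound 2 `COc1ccccc1-c1cc(O)c2cccnc2n1` is made of the same atoms as compound 3, joined differently; how the two cores differ is not broken down here. In this assay compound 2 gives 67600 nM, by far the highest number among the three measured compounds.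

Compound 4 `COc1ccccc1-c1cc(O)c2cc(C)cnc2n1` has not yet been measured. It stands to compound 2 as compound 1 stands to compound 3, through (methyl in place of hydrogen on an aromatic carbon), the same change at the same place. Because a 1.2-fold lower number from compound 3 to compound 1 (0.09 log units; within the scatter) lay within the scatter, the expected step in this assay is small, namely a 1.2-fold lower number from compound 2 to compound 4 (0.09 log units; within the scatter). Compound 4 is therefore expected to give around 55000 nM, with a likely range from 15000 nM to 200000 nM, remaining a weak inhibitor of growth.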

Compound 4, concentration for 50% growth inhibition: 27500 nM
Estimate against measurement, compound 4: 2.0-fold (0.30 log units) above; the measured number falls inside the stated range.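

In this assay, adding the methyl gives a 2.5-fold lower number from compound 2 to compound 4 (0.39 log units; beyond the scatter), a modest step that lies beyond the scatter, even though the same change on the other core stayed within it. Set side by side, however, the two steps cannot be told apart: the same change on two cores in this assay, a 1.2-fold lower number (0.09 log units; within the scatter) from compound 3 to compound 1 and a 2.5-fold lower number (0.39 log units; beyond the scatter) from compound 2 to compound 4, 2.0-fold (0.30 log units) apart, within the scatter of two such steps The change therefore carries from one core to the other without any measurable difference in size, but two pairs show only that these two results agree, not that a methyl at this place will give the same step on every core in the series.

The compounds shown leave open whether a different group on the same aromatic carbon, such as an ethyl, a chlorine or an amine, would give a step of similar size. They also leave open how the methyl would behave if the methoxy group on the outer ring gave way to another group, such as a carboxylic acid.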